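This account rests on a few compounds, and the source may have more. Where it says the series, first, only, none or still open, it means among the compounds named here.

Compound 1 `CC(C)CCn1nc(-c2cccs2)c(O)c(C2=NS(=O)(=O)c3cc(N(C)S(C)(=O)=O)ccc3N2)c1=O`: in an ADME assay on Huh-7 cells (Homo sapiens) for cytotoxicity, with a stated time of 72 h (on this read-out higher numbers stand for lower toxicity in this test and lower numbers for higher toxicity in this test), compound 1 gives > 33000 nM, which is a limit of the assay.
Compound 2 `CC(C)CCn1nc(-c2cccs2)c(O)c(C2=NS(=O)(=O)c3cc(S(N)(=O)=O)ccc3N2)c1=O`: in this assay compound 2 gives > 33000 nM, again a limit.
Compound 3 `CC(C)CCn1nc(-c2ccn(C)c2)c(O)c(C2=NS(=O)(=O)c3cc(NS(C)(=O)=O)ccc3N2)c1=O`: in this assay compound 3 gives > 1000 nM, also a limit.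

Compound 3 therefore stands at the limit of > 1000 nM in this assay, at which 1 of the 3 values shown sits, whereas compounds 1 and 2 stand at the limit of > 33000 nM in this assay, at which 2 of the 3 values shown sit. Compound 4 `CC(C)CCc1nn(CCC(C)C)c(=O)c(C2=NS(=O)(=O)c3cc(NS(C)(=O)=O)ccc3N2)c1O` differs from compound 3 by isopentyl in place of 1-methyl-1H-pyrrol-3-yl on an aromatic carbon. Among the measured compounds shown here, the only measured step, a step that the two limits leave unreadable from compound 1 to compound 2, concerns a different position and its size cannot be read. For the measured compounds named here, no measured step bears on the change from compound 3 to compound 4, so no direction beyond the scatter can be expected. Compound 4 is estimated at 20000 nM with a range from 3000 nM to 60000 nM. The expected step is a step that the limit leaves unreadable from compound 3 to compound 4, with a limit again likely.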

Compound 4, half-maximal cytotoxic concentration: > 33000 nM
Compound 4: only a limit was reported (the forecaster's own chance of this, stated with the estimate: 70%); at least 1.6-fold (0.21 log units) between middle value and limit.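

Among the compounds shown here, compound 3 and compound 4 are both reported only as limits of the assay, so no step between them can be read. Going by these compounds, whether isopentyl in place of 1-methyl-1H-pyrrol-3-yl shifts the result in this assay stays open.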